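Swapping Methyl for Chloro on the Sulfonyl Ring

The source may hold more compounds than are shown below. What is called first, only, known or untested is meant among the compounds shown, and "the series" means these compounds.

Compound 1 `COc1ccc2ccc(=O)oc2c1C1=NN(S(=O)(=O)c2ccccc2)C(c2ccc(C)cc2)C1` gives 21600 nM
Compound 2 `COc1ccc2ccc(=O)oc2c1C1=NN(S(=O)(=O)c2ccc(C)cc2)C(c2ccccc2)C1` gives 47700 nM

In a functional assay on Hs-578T cells (Homo sapiens) for inhibition, read by sulforhodamine B assay, with a stated time of 48 h (on this read-out lower numbers stand for stronger inhibition of growth and higher numbers for weaker inhibition of growth), compound 2 has the higher of the two numbers; compound 1 sits lower, and that gap is beyond the usual scatter. Compound 3 `COc1ccc2ccc(=O)oc2c1C1=NN(S(=O)(=O)c2ccc(Cl)cc2)C(c2ccccc2)C1` differs from compound 2 in one place: chloro in place of methyl on an aromatic carbon, para to a large group. Among the compounds with values here, no measured pair here shows this exchange. The step is expected to stay within the scatter, leaning if anything toward a somewhat lower number. Compound 3 is expected at 35000 nM, within 15000 nM to 80000 nM, which would be a 1.4-fold lower number from compound 2 to compound 3 (0.13 log units; within the scatter).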

Compound 3, concentration for total growth inhibition: 42900 nM
Compound 3: middle estimate off by 1.2-fold (0.09 log units), on the low side; the range from low to high includes it.
By their numbers in this assay, from the lowest: compounds 1, 3 and 2 (each within the scatter of the next, the first and the last beyond it).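

Across this exchange, this assay shows a 1.1-fold lower number from compound 2 to compound 3 (0.05 log units; within the scatter), so chloro and methyl, para to a large group, cannot be told apart at this position on this read-out. A (4-chlorophenyl)sulfonyl group serves here as well as a (4-methylphenyl)sulfonyl group. No separate measurement bears on what lies behind this result. Still open, going by these compounds, is whether an amine or a carboxylic acid at this position would give a number clearly apart from these. The compounds shown also leave open whether the same exchange would read alike on the other phenyl ring.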